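Swapping the Amide Substituent on a Long Fatty Acid Chain

The source may hold more compounds than are shown below. What is called first, only, known or untested is meant among the compounds shown, and "the series" means these compounds.

Two fatty acid amides have been measured in a functional assay on NCI/ADR-RES cells (Homo sapiens) for antiproliferative activity, read by sulforhodamine B assay, with a stated time of 48 h; on this read-out lower numbers stand for stronger inhibition of growth and higher numbers for weaker inhibition of growth. Compound 1 `CCCCCCCCCCCCCCCC(=O)N1CCCC1` gives 4.6 ug/mL. Compound 2 `CCCCCCCCCCCCCCCCCC(=O)N[C@H](C)c1ccccc1` gives 25.7 ug/mL, the higher of the two numbers and so the weaker growth inhibitor, standing beyond the usual scatter from compound 1.

Compound 3 `CCCCCCCCCCCCCCCCCC(=O)N1CCCC1` has not yet been measured. Relative to compound 2, the change is pyrrolidin-1-yl in place of (1-phenylethyl)amino on a carbonyl carbon. Compound 1 also carries a pyrrolidin-1-yl on its carbonyl carbon, attached to a saturated chain, and it is the stronger inhibitor of the two measured compounds. Among the measured compounds shown here, with only two numbers in hand, the expectation rests on that single comparison, and the step is expected to be a clear move toward stronger growth inhibition, beyond the scatter, rather than a small one. The step expected from compound 2 to compound 3 in this assay is a 4.0-fold lower number from compound 2 to compound 3 (0.60 log units; beyond the scatter). Compound 3 is therefore estimated to give 6.5 ug/mL in this assay, with a likely range from 2.5 ug/mL to 17 ug/mL.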

Compound 3, concentration for 50% growth inhibition: 7.1 ug/mL
Beside the measured number, compound 3's estimate is 1.1-fold (0.04 log units) below it; low and high end bracket the measured number.
By their numbers in this assay, from the lowest: compounds 1 and 3 (each within the scatter of the next); then compound 2.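

Compound 3 carries the same saturated chain as compound 2, so in this assay the change of group on the carbonyl carbon alone gives a 3.6-fold lower number from compound 2 to compound 3 (0.56 log units; beyond the scatter) and shows that this position matters by itself, which the earlier pair could not show since its members also differ in chain length. Keeping pyrrolidin-1-yl in place and putting ethyl in place of hydrogen on a saturated chain carbon gives a 1.5-fold higher number from compound 1 to compound 3 (0.19 log units; within the scatter) and so leaves the read-out within the scatter for this one lengthening of the chain. No independent measurement is available to explain either result.

The compounds shown leave open whether the ring itself counts, since a piperidin-1-yl or an open dimethylamino group on the same carbonyl carbon could separate the effect of ring size from that of the ring. They also leave open how far the chain can change, as a much shorter chain, or a carboxylic acid in place of the amide, would test whether the pyrrolidin-1-yl amide needs a long chain at all.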